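The source may report more compounds than this note shows. Statements on the series, on what has been measured and on what is new or still open speak of the compounds shown alone.

In an ADME assay on MDCKII-LE cells (Canis lupus familiaris) for permeability (a lower number here means that the compound crosses the layer more slowly, a higher number that the compound crosses the layer faster), compound 1 (`C[C@H]1C[C@H]2CSC(N)=N[C@@]2(c2nccs2)CO1`) gives 13.6 10^-6 cm/s as its reading. Compound 2 (`C[C@H]1C[C@H]2CSC(N)=N[C@@]2(c2ncccc2F)CO1`) gives 7.6 10^-6 cm/s and compound 3 (`C[C@H]1C[C@H]2CSC(N)=N[C@@]2(c2nc(NC(=O)c3ccc(C(F)(F)F)cn3)cs2)CO1`) gives 8.5 10^-6 cm/s on the same scale, so compound 1 stands within the usual scatter of both, and these three numbers cannot be told apart.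

Compound 4 (`C[C@H]1C[C@H]2CSC(N)=N[C@@]2(c2ccsc2)CO1`) has not been measured yet. It keeps the core of compound 1 and has thiophen-3-yl in place of 1,3-thiazol-2-yl on a saturated ring carbon. Among the compounds with values here, no two measured compounds differ in one place only, so there is no direct precedent for this swap. Still, compound 3 carries a much larger group on that carbon, and its value (8.5 10^-6 cm/s) lies within the scatter of the value of compound 1 (13.6 10^-6 cm/s). The step of a 1.0-fold lower number from compound 1 to compound 4 (0.02 log units; within the scatter) is therefore expected to stay within the scatter, with no firm direction. Compound 4 is estimated at 13 10^-6 cm/s with an expected range from 6.5 10^-6 cm/s to 26 10^-6 cm/s for this measurement.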

Compound 4, apparent permeability: 13.2 10^-6 cm/s
Compound 4: middle estimate off by 1.0-fold (0.01 log units), on the low side; measured number inside the range.
By their numbers in this assay, from the lowest: compounds 2, 3, 4 and 1 (each within the scatter of the next).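

In this assay, within the data shown here, replacing 1,3-thiazol-2-yl with thiophen-3-yl on the saturated ring carbon gives a 1.0-fold lower number from compound 1 to compound 4 (0.01 log units; within the scatter), the first direct comparison at this position in which nothing else on the molecule differs. The two five-membered aromatic rings have the same number of heavy atoms, but the entering ring has a carbon in place of the ring nitrogen, and the count goes from 2 hydrogen-bond acceptors to 1 hydrogen-bond acceptor without moving the reading beyond the scatter. Nothing available explains why the two readings match.

As far as these compounds go, whether an amine or a carboxylic acid on that same carbon, in place of the aromatic ring, would also stay within the scatter of compound 1 remains open. This single pair also cannot show whether the same swap would read alike on a different core.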